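Cyclopropyl to allyl on the amide nitrogen of compound 2

A few compounds are considered here, and "the series" means these few. Any claim that something is new, unique, unknown or untested is made for them only; others in the source may bear on it.

Compound 2 `C/C(C(=O)NC1CC1)=C(/C)c1ccccc1` is one of three measured compounds sharing a core with varying aromatic substituents. In a toxicity assay on the whole organism (strain Icem-CET (SPF Caw)) for cytotoxicity, with Mus musculus as the target (on this read-out higher numbers stand for an effect only at larger amounts of compound and lower numbers for an effect already at smaller amounts), compound 2 gives 250 mg/kg. Compound 3 `C/C(C(=O)NC1CC1)=C(/C)c1ccc(C)cc1` gives 300 mg/kg in this assay, and the step of a 1.2-fold higher number from compound 2 to compound 3 (0.08 log units; within the scatter) lies within the scatter. Compound 1 `C/C(C(=O)NC1CC1)=C(/C)c1ccc(Br)cc1` gives 600 mg/kg, and the step of a 2.4-fold lower number from compound 1 to compound 2 (0.38 log units; beyond the scatter) is beyond the scatter, so compound 2 sits apart only from compound 1 on these numbers.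

Compound 4 `C=CCNC(=O)/C(C)=C(\C)c1ccccc1` differs from compound 2 at the amide nitrogen: allyl in place of cyclopropyl on an amide-type nitrogen. Within the data shown here, none of the measured steps touches this part of the molecule; all three change only the aromatic substituent, and of those, a 2.0-fold lower number from compound 1 to compound 3 (0.30 log units; within the scatter) and a 1.2-fold higher number from compound 2 to compound 3 (0.08 log units; within the scatter) stayed within the scatter. There is therefore nothing in the measured set that points to a change in this assay, and no step beyond the scatter is expected.

Compound 4 is estimated at 250 mg/kg, with a range from 120 mg/kg to 520 mg/kg, which means an expected step of no change at the digits printed from compound 2 to compound 4 (within the scatter).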

Compound 4, dose for half-maximal effect: 300 mg/kg
Beside the measured number, compound 4's estimate is 1.2-fold (0.08 log units) below it; low and high end bracket the measured number.
By their numbers in this assay, from the lowest: compounds 2, 3, 4 and 1 (each within the scatter of the next, the first and the last beyond it).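

In this assay, among these compounds, the step of a 1.2-fold higher number from compound 2 to compound 4 (0.08 log units; within the scatter) is the only reading here of a change on the amide nitrogen, as the earlier steps altered only the aromatic substituent. It shows that replacing the ring of cyclopropyl with the open allyl chain, at an equal count of heavy atoms, leaves the number within the scatter at this position. Nothing available accounts for this result.

Going by these compounds, whether a longer chain such as hexyl, a benzyl group or a chain carrying an amine on this nitrogen would move the number beyond the scatter remains open. On these data alone, it is also open whether allyl in place of cyclopropyl reads the same with the bromo group of compound 1 on the aromatic ring.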